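This account rests on a few compounds, and the source may have more. Where it says the series, first, only, none or still open, it means among the compounds named here.

Compound 1 `Cc1cc(NC(=O)N2CCN(C)CC2)ccc1N1CCC(N2CCCC2C)C1`: 12.7 nM in an assay on CHO cells for displacement of a labelled ligand from histamine receptor H3 (Macaca mulatta), read by scintillation counting, with a stated time of 1 h; on this read-out lower numbers stand for stronger inhibition and higher numbers for weaker inhibition. Compound 2 `Cc1cc(NC(=O)NCc2cccs2)ccc1N1CCC(N2CCCC2C)C1`: 8.4 nM.

Compound 2 shows the lowest of the two numbers, but the step of a 1.5-fold lower number from compound 1 to compound 2 (0.18 log units; within the scatter) lies within the scatter, so the two compounds cannot be ranked. Compound 3 `Cc1cc(NC(=O)NCc2cc(Cl)cc(Cl)c2)ccc1N1CCC(N2CCCC2C)C1` differs from compound 2 by 3,5-dichlorophenyl in place of thiophen-2-yl on a saturated chain carbon bound to an amide-type nitrogen. Among the measured compounds shown here, the only measured step, a 1.5-fold lower number from compound 1 to compound 2 (0.18 log units; within the scatter), concerns a different change on the carbonyl carbon and does not bear directly on this exchange; no measured pair varies the group on the saturated chain carbon bound to the amide-type nitrogen. Compound 3 is therefore expected to move by a 1.1-fold lower number from compound 2 to compound 3 (0.02 log units; within the scatter), no more than the scatter. The estimate for compound 3 is 8 nM, ranging from 3 nM to 25 nM.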

Compound 3, inhibition constant: 28.8 nM
The estimate for compound 3 lay 3.6-fold (0.56 log units) below the measured number, outside the stated range (above it).
By their numbers in this assay, from the lowest: compounds 2 and 1 (each within the scatter of the next); then compound 3.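

In this assay, among the compounds shown here, the group on the saturated chain carbon bound to an amide-type nitrogen proves to count: 3,5-dichlorophenyl in place of thiophen-2-yl gives a 3.4-fold higher number from compound 2 to compound 3 (0.54 log units; beyond the scatter), the first step here beyond the scatter. Set against the 4-methylpiperazin-1-yl group on the carbonyl carbon, (3,5-dichlorobenzyl)amino gives a 2.3-fold higher number from compound 1 to compound 3 (0.36 log units; beyond the scatter), so the carbonyl substituent also separates compounds once this group is present. Nothing available here accounts for these shifts.

The compounds shown leave open whether the chlorine atoms or the change of ring drives the weaker number. On these data alone, how a plain benzyl group or a 2-(thiophen-2-yl)ethyl chain would read also remains unknown.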